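This account rests on a few compounds, and the source may have more. Where it says the series, first, only, none or still open, it means among the compounds named here.

Measured in an ADME assay on cells (Hepatocyte, Mus musculus) for metabolic stability; a higher number here means that the compound lasts longer, a lower number that the compound disappears faster:
- Compound 1 `O=c1cc(N2CCN(CC3CCC(NS(=O)(=O)c4ccccc4)CC3)CC2)sc2c([N+](=O)[O-])cc(C(F)(F)F)cc12`: > 1.55 h, a limit
- Compound 2 `O=C(NC1CCC(CN2CCN(c3cc(=O)c4cc(C(F)(F)F)cc([N+](=O)[O-])c4s3)CC2)CC1)c1ccccc1`: > 1.55 h, a limit

Compound 2 stands only at a limit and has no exact half-life, and both compounds sit at the limit of > 1.55 h in this assay, at which 2 of the 2 values shown sit. Compound 3 `Cc1ccc(C(=O)OC2CCC(CN3CCN(c4cc(=O)c5cc(C(F)(F)F)cc([N+](=O)[O-])c5s4)CC3)CC2)cc1` differs from it as follows: ((4-methylphenyl)carbonyl)oxy in place of benzamido on a saturated ring carbon. It carries ((4-methylphenyl)carbonyl)oxy in place of benzamido on a saturated ring carbon. For the measured compounds named here, the sole measured step, a step that the two limits leave unreadable from compound 1 to compound 2, is a different change, benzoyl in place of phenylsulfonyl on an amine nitrogen, and gives no size to carry over. No change beyond the scatter is therefore expected in this assay, though with wide uncertainty. The expected step is a step that the limit leaves unreadable from compound 2 to compound 3. For compound 3 the estimated half-life is 1.6 h, with an expected range of 0.6 h to 4 h.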

Compound 3, half-life: 0.202 h
Estimate against measurement, compound 3: 7.9-fold (0.90 log units) above; the measured number lies below the stated range.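

In this assay, the earlier pair gave no readable step, but this saturated ring carbon now proves sensitive to what it carries: ((4-methylphenyl)carbonyl)oxy in place of benzamido gives an at least 7.6-fold lower number from compound 2 to compound 3 (0.88 log units; beyond the scatter), and in place of (phenylsulfonyl)amino it gives an at least 7.6-fold lower number from compound 1 to compound 3 (0.88 log units; beyond the scatter). Compound 1 and compound 2 both stand at a limit, so these steps give only a least size: the limit of > 1.55 h in this assay, at which 2 of the 3 values shown sit.

The compounds shown leave open whether the oxygen link or the methyl group on the ring accounts for the drop, and where a 4-methylbenzamido group or a carbamate on this carbon would stand.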